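Pyrrolidin-1-yl in place of diethylamino: expected dose

A few compounds are considered here, and "the series" means these few. Any claim that something is new, unique, unknown or untested is made for them only; others in the source may bear on it.

Values in a functional assay on the whole organism with Mus musculus as the target (a higher number here means that more compound is needed for the effect, a lower number that less compound is needed), follow
compound 1 `Cc1cc(-c2ccccc2)nnc1NCCCN` gives 50 mg/kg
compound 2 `CCN(CC)CCNc1nnc(-c2ccccc2)cc1C` gives > 30 mg/kg

Compound 2 has only a limit (> 30 mg/kg) and no number. Among the measured compounds shown here, the one measured step (a step that the limit leaves unreadable from compound 1 to compound 2) gives no size to carry over, and the sole evidence on it is the limit itself (the limit of > 30 mg/kg in this assay, at which 1 of the 2 values shown sits). Compound 3 `Cc1cc(-c2ccccc2)nnc1NCCN1CCCC1` carries pyrrolidin-1-yl in place of diethylamino (pyrrolidin-1-yl in place of diethylamino on a saturated chain carbon, two bonds along the chain from a nitrogen on an aromatic ring) on a saturated chain carbon, two bonds along the chain from a nitrogen on an aromatic ring. In this assay no step beyond the scatter is expected, and no direction can be given (expected step: a step that the limit leaves unreadable from compound 2 to compound 3). The estimate for compound 3 is 40 mg/kg (expected range 15 mg/kg to 100 mg/kg).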

Compound 3, dose for half-maximal effect: > 30 mg/kg
Compound 3 ended at the assay's limit; the forecaster's own chance of this, stated with the estimate: 45%; the middle value is on the limit's open side.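

In this assay no step can be read among compound 1, compound 2 and compound 3, because compound 2 and compound 3 carry only limits: the limit of > 30 mg/kg in this assay, at which 2 of the 3 values shown sit. From the compounds shown here alone, how far pyrrolidin-1-yl and diethylamino differ, and how either compares with the chain end of compound 1, stays open.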